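The compounds below may be only part of what the source reports. "The series", "measured", "known", "first", "only" and "open" are said of these compounds alone.

Measured so far in an ADME assay on CCRF-HSB-2 cells (Homo sapiens) for cytotoxicity, with a stated time of 7 days (a lower number here means that less compound is tolerated, a higher number that more compound is tolerated), are two compounds. Compound 1, `Nc1nc(NCc2ccccc2)c2ncn(/C=C3/CC3(CO)CO)c2n1`, gives > 20000 nM. Compound 2, `CC(C)CNc1nc(N)nc2c1ncn2/C=C1/CC1(CO)CO`, gives > 20000 nM.

For compound 1 the value in this assay is a limit of the assay, not a number: > 20000 nM. For compound 2 the value is likewise only a limit: > 20000 nM. Within the data shown here, the one measured step, a step that the two limits leave unreadable from compound 1 to compound 2, isopropyl in place of phenyl on a saturated chain carbon bound to a nitrogen on an aromatic ring, therefore has no readable size, since (the limit of > 20000 nM in this assay, at which 2 of the 2 values shown sit).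

Compound 3, `Nc1nc(SCc2ccccc2)c2ncn(/C=C3/CC3(CO)CO)c2n1`, differs from compound 1 by benzylsulfanyl in place of benzylamino on an aromatic carbon. Among the measured compounds shown here, no measured step covers an exchange of this kind on an aromatic carbon; the only step available is unreadable, and both values shown stand at the same limit.

With nothing in the measured steps pointing in either direction, compound 3 is expected to give a step that the limit leaves unreadable from compound 1 to compound 3 that does not go beyond the scatter. Compound 3 is therefore estimated at 25000 nM in this assay, within a range of 10000 nM to 60000 nM, and most likely reported again as a limit rather than a number.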

Compound 3, half-maximal cytotoxic concentration: > 100000 nM
Compound 3 ended at the assay's limit; the forecaster's own chance of this, stated with the estimate: 75%; middle value at least 4.0-fold (0.60 log units) from the limit.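

In this assay compound 3 gives > 100000 nM, a limit of the assay and not a number. No step among compound 1, compound 2 and compound 3 can be read, since every value is only a limit: the limit of > 100000 nM in this assay, at which 1 of the 3 values shown sits.

The compounds shown leave open whether benzylsulfanyl in place of benzylamino on the shared core changes the tolerated concentration at all.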